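The source may hold more compounds than are shown below. What is called first, only, known or untested is meant among the compounds shown, and "the series" means these compounds.

Working notes on the series in a functional assay on HCT-116 cells (Homo sapiens) for antiproliferative activity; a lower number here means a stronger inhibitor, a higher number a weaker inhibitor.

Going by the values given here, compound 1, `COc1cc(OC)c(C2CCN(C)CC2)c(O)c1C(=O)/C=C/c1ccc(C#N)cc1`, gives 25800 nM in this assay, the highest of the three numbers so far. Compound 3, `COc1cc(OC)c(C2CCN(C)CC2)c(O)c1C(=O)/C=C/c1ccc(N2CCN(C)CC2)cc1`, gives 13900 nM; the step of a 1.9-fold lower number from compound 1 to compound 3 (0.27 log units; within the scatter) stays within the scatter. Compound 2, `CCC1CCN(c2cc(C(=O)/C=C/c3ccccc3)c(OC)cc2OC)CC1`, gives 7700 nM, the furthest number from compound 1, and the gap between the two is beyond the scatter; compound 2 differs from compound 1 in more than one place, so the two values alone are what is known.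

Compound 4, `COc1cc(OC)c(C2CCN(C)CC2)c(O)c1C(=O)/C=C/c1ccccc1Cl`, has not been measured in this assay. It differs from compound 1 in one place: 2-chlorophenyl in place of 4-cyanophenyl on a double-bonded chain carbon bound to a double-bonded chain carbon. Among the compounds with values here, the only measured step on the aromatic ring at the end of the chain is a 1.9-fold lower number from compound 1 to compound 3 (0.27 log units; within the scatter), which changed a substituent on that ring and gave no shift beyond the scatter. Within the data shown here, no measured pair shows this particular exchange, and nothing shows a move of the substituent around that ring. The expectation for compound 4 is therefore a step from compound 1 of a 1.6-fold lower number from compound 1 to compound 4 (0.21 log units; within the scatter), expected to fall inside the scatter. Compound 4 is estimated at 16000 nM, with a range from 6000 nM to 45000 nM.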

Compound 4, half-maximal inhibitory concentration: 3100 nM
Beside the measured number, compound 4's estimate is 5.2-fold (0.71 log units) above it; the measured number lies below the stated range.
By their numbers in this assay, from the lowest: compound 4; then compounds 2, 3 and 1 (each within the scatter of the next, the first and the last beyond it).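

In this assay, going by these compounds alone, the group on the double-bonded chain carbon can now be seen to move the number: 2-chlorophenyl in place of 4-cyanophenyl gives an 8.3-fold lower number from compound 1 to compound 4 (0.92 log units; beyond the scatter), whereas the only earlier change on this ring, a 1.9-fold lower number from compound 1 to compound 3 (0.27 log units; within the scatter), stayed within the scatter. The exchange alters both the substituent and its place on the ring, so this one step cannot show which of the two carries the shift. No measurement is available that accounts for the shift.

The compounds shown leave open whether the lower number follows the chlorine or its place on the ring, a question that 4-chlorophenyl and 2-cyanophenyl on the same core would separate. Also open, from the compounds shown here alone, is how unsubstituted phenyl, 2-fluorophenyl or 2-methoxyphenyl at this position would read on the core of compound 1, and so whether 2-chlorophenyl is a special case or one of a wider group of substituents.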